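Halogen Trimming on a Benzylamine Series in Renal Cells

The source may hold more compounds than are shown below. What is called first, only, known or untested is meant among the compounds shown, and "the series" means these compounds.

Among the measured compounds shown here, compound 1 `Nc1cc(N)c2nc(-c3ccccc3)c(NCc3ccc(Cl)c(Cl)c3)nc2c1` is the only member of this small set with a measured number in a functional assay on 786-0 cells (Homo sapiens) for inhibition, read by sulforhodamine B assay, with a stated time of 48 h (a higher number here means a weaker inhibitor of growth, a lower number a stronger inhibitor of growth), where compound 1 gives 30200 nM. Compound 2 `COc1cc(CNc2nc3cc(N)cc(N)c3nc2-c2ccccc2)cc(OC)c1OC` reaches only a limit in this assay, compound 2 standing at < 50200 nM. Compound 3 `CCOC(=O)[C@H](CCC(=O)O)NC(=O)c1ccc(CNc2nc3cc(N)cc(N)c3nc2-c2ccccc2)cc1` likewise gives only a limit in this assay, with compound 3 at < 100000 nM. For the measured compounds named here, no measured pair differs in a single place, so no step size is known from these data. Compound 4 `Nc1cc(N)c2nc(-c3ccccc3)c(NCc3ccc(F)cc3)nc2c1` differs from compound 1 by 4-fluorophenyl in place of 3,4-dichlorophenyl on a saturated chain carbon bound to a nitrogen on an aromatic ring. A modest loss of growth inhibition, somewhat beyond the usual scatter, is expected for this change. The estimated step is a 1.8-fold higher number from compound 1 to compound 4 (0.26 log units; within the scatter). Compound 4 is therefore expected to give about 55000 nM, within a range from 18000 nM to 100000 nM.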

Compound 4, concentration for total growth inhibition: 61700 nM
For compound 4 the middle estimate is 1.1-fold (0.05 log units) below the measured one; measured number inside the range.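

In this assay, among the compounds shown here, 4-fluorophenyl in place of 3,4-dichlorophenyl on a saturated chain carbon bound to a nitrogen on an aromatic ring gives a 2.0-fold higher number from compound 1 to compound 4 (0.31 log units; beyond the scatter) and is the first step in this set that can be read. It shows that, with the shared core unchanged, growth inhibition responds modestly to this change in the halogenated phenyl group. Nothing shown gives a cause for this step. From the compounds shown here alone, it remains open whether a single chlorine, as in 4-chlorophenyl, would keep the number of compound 1. Going by these compounds, how an unsubstituted phenyl or a 4-methoxyphenyl would read at this place also remains open.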